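A few compounds are considered here, and "the series" means these few. Any claim that something is new, unique, unknown or untested is made for them only; others in the source may bear on it.

Of the compounds shown here, two with a shared core have been measured so far, compound 1 `O=C(CCCOc1no[n+]([O-])c1S(=O)(=O)c1ccccc1)NO` and compound 2 `O=C(COCCOc1no[n+]([O-])c1S(=O)(=O)c1ccccc1)NO`. In a functional assay on HEL cells (Homo sapiens) for inhibition, read by MTT assay, with a stated time of 48 h (a higher number here means a weaker inhibitor, a lower number a stronger inhibitor), compound 1 gives 670 nM and compound 2 gives 6790 nM, so compound 2 has the higher number of the pair and is the weaker inhibitor. Compound 3 `CC(C)(COc1no[n+]([O-])c1S(=O)(=O)c1ccccc1)C(=O)NO` is still unmeasured. It carries 1-(hydroxycarbamoyl)-1-methylethyl in place of ((hydroxycarbamoyl)methoxy)methyl on a saturated chain carbon bound to an oxygen on an aromatic ring. Within the data shown here, one measured step bears on this change: a 10-fold higher number from compound 1 to compound 2 (1.01 log units; beyond the scatter), a large step that came with putting oxygen into the chain. Compound 3 has no oxygen in that chain, but its chain also differs from that of compound 1, so only part of that step is expected to be reversed. The expected change is a 3.4-fold lower number from compound 2 to compound 3 (0.53 log units; beyond the scatter), towards a lower number. For compound 3, the estimated value is 2000 nM, with an expected range of 500 nM to 8000 nM.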

Compound 3, half-maximal inhibitory concentration: 5010 nM
Beside the measured number, compound 3's estimate is 2.5-fold (0.40 log units) below it; the measured number falls inside the stated range.
By their numbers in this assay, from the lowest: compound 1; then compounds 3 and 2 (each within the scatter of the next).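

In this assay, the change shows as a 1.4-fold lower number from compound 2 to compound 3 (0.13 log units; within the scatter) and so leaves the number essentially unchanged, even though the chain oxygen of compound 2 is gone. Set against compound 1, the same 1-(hydroxycarbamoyl)-1-methylethyl group gives a 7.5-fold higher number from compound 1 to compound 3 (0.87 log units; beyond the scatter) and therefore does not recover the lower number, so the absence of a chain oxygen is not enough on its own to match compound 1 among these three compounds. No measurement shown here explains the difference between these chains.

The compounds shown leave open whether a single methyl on the chain, or a longer all-carbon chain ending in hydroxycarbamoyl, would stay close to compound 1. They also leave open how the number would respond to a carboxylic acid in place of the hydroxycarbamoyl group on the chain of compound 1.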